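Methyl to hydrogen on the enone chain, second pair

The source may hold more compounds than are shown below. What is called first, only, known or untested is meant among the compounds shown, and "the series" means these compounds.

Measured so far:
compound 1, `C=C(CC)C(=O)c1ccc(OCc2nc(-c3ccc([N+](=O)[O-])cc3)cs2)c(C)c1C`: 3600 nM
compound 2, `C=C(C)C(=O)c1ccc(OCc2nc(-c3ccc([N+](=O)[O-])cc3)cs2)c(C)c1C`: 5100 nM
compound 3, `C=C(CC)C(=O)c1ccc(OCc2nc(-c3ccc4ccccc4c3)cs2)cc1Cl`: 900 nM

All three were run in a functional assay on HL-60 cells (Homo sapiens) for inhibition, read by trypan blue exclusion, with a stated time of 72 h; on this read-out lower numbers stand for stronger inhibition of growth and higher numbers for weaker inhibition of growth. Compound 1 and compound 2 share one core and differ by hydrogen in place of methyl on a saturated chain carbon bound to a double-bonded chain carbon; that step gave a 1.4-fold higher number from compound 1 to compound 2 (0.15 log units; within the scatter). Compound 3 has a different core; how its core differs from that of compound 1 is not broken down here. Against the others compound 3 gives the lowest number, with the gaps to compound 1 and compound 2 both beyond the scatter.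

Compound 4, `C=C(C)C(=O)c1ccc(OCc2nc(-c3ccc4ccccc4c3)cs2)cc1Cl`, is not yet measured. It differs from compound 3 by hydrogen in place of methyl on a saturated chain carbon bound to a double-bonded chain carbon, the same change as from compound 1 to compound 2, at the same place. For the measured compounds named here, the only precedent for this change is the pair compound 1 to compound 2, where the step stayed within the scatter, so the expected step from compound 3 to compound 4 in this assay is a 1.3-fold higher number from compound 3 to compound 4 (0.12 log units; within the scatter), resting on a 1.4-fold higher number from compound 1 to compound 2 (0.15 log units; within the scatter). The estimate for compound 4 in this assay is 1200 nM, expected between 600 nM and 2500 nM.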

Compound 4, concentration for 50% growth inhibition: 2900 nM
Beside the measured number, compound 4's estimate is 2.4-fold (0.38 log units) below it; the measured number lies above the stated range.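

In this assay, hydrogen in place of methyl on a saturated chain carbon bound to a double-bonded chain carbon gave a 3.2-fold higher number from compound 3 to compound 4 (0.51 log units; beyond the scatter), a step beyond the scatter on this core, whereas the same change on the core of compound 1 stayed within it. Both steps run in the same direction, yet they cannot be told apart: the same change on two cores in this assay, a 1.4-fold higher number (0.15 log units; within the scatter) from compound 1 to compound 2 and a 3.2-fold higher number (0.51 log units; beyond the scatter) from compound 3 to compound 4, 2.3-fold (0.36 log units) apart, within the scatter of two such steps. The change thus carries over with the same sign on two cores, but this does not show that the core of compound 3 responds more strongly, and two pairs fix no general size for the step.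

Still open, from the compounds shown here alone, is whether a longer chain than the ethyl of compound 3, such as propyl or butyl, lowers the number further, and what an amine or a hydroxyl group on that chain would do. Also open, going by these compounds, is which of the parts that differ between the two cores, if any, bears on the size of the step.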